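Thiol-capping in a naphthyl glycoside antiproliferative series

The compounds below may be only part of what the source reports. "The series", "measured", "known", "first", "only" and "open" are said of these compounds alone.

Measured compounds:
- compound 1 `O[C@@H]1[C@@H](O)[C@H](Oc2ccc3cc(S)ccc3c2)OC[C@H]1O`: 135 uM
- compound 2 `Oc1ccc(S[C@@H]2OC[C@@H](O)[C@H](O)[C@H]2O)c2ccccc12`: 160 uM
- compound 3 `Oc1cccc2cccc(S[C@@H]3OC[C@@H](O)[C@H](O)[C@H]3O)c12`: 225 uM

In a functional assay on T-24 cells (Homo sapiens) for antiproliferative activity, read by crystal violet staining, with a stated time of 96 h (on this read-out higher numbers stand for an effect only at larger amounts of compound and lower numbers for an effect already at smaller amounts), compound 1 gives 135 uM, the lowest of the three numbers. Compound 2 gives 160 uM and compound 3 gives 225 uM in this assay, and both of these sit within the scatter of the number for compound 1, so no order among the three can be read from them. The three compounds differ in more than one place, and no single-point comparison between measured compounds is available.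

Compound 4 `CCCSc1ccc2cc(O[C@@H]3OC[C@@H](O)[C@H](O)[C@H]3O)ccc2c1` differs from compound 1 by propyl in place of hydrogen on a sulfur. Within the data shown here, nothing among the measured compounds shows what capping the sulfur with a chain does here. Given that all three measured numbers fall close together, the step from compound 1 to compound 4 is expected to be small, and the estimate places it at a 1.1-fold lower number from compound 1 to compound 4 (0.05 log units; within the scatter), that is none beyond the scatter. Compound 4 is therefore estimated at 120 uM in this assay, with a range from 45 uM to 320 uM.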

Compound 4, concentration for half-maximal effect: 40 uM
Compound 4: the middle estimate sits 3.0-fold (0.48 log units) above what was measured; the whole stated range lies above it.
By their numbers in this assay, from the lowest: compound 4; then compounds 1, 2 and 3 (each within the scatter of the next).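

Capping the sulfur with propyl gives the first step in the series that lies beyond the scatter in this assay (a 3.4-fold lower number from compound 1 to compound 4 (0.53 log units; beyond the scatter)). This position on the sulfur therefore accepts a chain, and the hydrogen there is not needed for a lower number, which compounds 1, 2 and 3 could not show, since they lie within the scatter of one another and differ in more than one place. Nothing at hand bears on the reason for this step.

Open, from the compounds shown here alone, is whether the step belongs to propyl itself or to any capping of the sulfur: a methyl, a longer chain such as hexyl, or a chain ending in an amine or a carboxylic acid would separate these. Also open, going by these compounds, is whether an oxygen in place of this sulfur would carry the propyl chain with the same result.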